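Extending the Alkyl Chain Further on a Shared Core

This account rests on a few compounds, and the source may have more. Where it says the series, first, only, none or still open, it means among the compounds named here.

Measured compounds:
Compound 1 `CCCCCCCCCCCCCSC[C@H](NC(C)=O)C(=O)CCl` — in a functional assay on MOLT-3 cells (Homo sapiens) (on this read-out lower numbers stand for stronger inhibition and higher numbers for weaker inhibition), compound 1 gives > 100000 nM, which is a limit of the assay and not a number.
Compound 2 `CCCCCCCCCCCCCCCCCCCCSC[C@H](NC(C)=O)C(=O)CCl` — in this assay compound 2 gives > 100000 nM, again a limit of the assay and not a number.

Compound 2 therefore stands at the limit of this assay, and so does every other value shown: the limit of > 100000 nM in this assay, at which 2 of the 2 values shown sit. For the measured compounds named here, the only measured step, a step that the two limits leave unreadable from compound 1 to compound 2, leaves no readable size, since both of its ends are limits.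

Compound 3 `CCCCCCCCCCCCCCCCCCCCCCSC[C@H](NC(C)=O)C(=O)CCl` differs from compound 2 by ethyl in place of hydrogen on a saturated chain carbon, ten or more bonds along the chain from a sulfur. Going by the values given here, the one measured step that bears on this change, a step that the two limits leave unreadable from compound 1 to compound 2, is of the same kind, a longer saturated chain at the same place, and it produced no number at either end. Nothing measured points to a step in either direction beyond the scatter, so compound 3 is expected to remain at the limit of this assay.

Compound 3 is estimated at 200000 nM, with a range from 100000 nM to 1000000 nM. For compound 3 this means an expected step that the limit leaves unreadable from compound 2 to compound 3, most likely reported again only as a limit.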

Compound 3, half-maximal inhibitory concentration: > 100000 nM
Compound 3: a limit, no number; the forecaster's own chance of this, stated with the estimate: 90%; the middle value lies beyond the limit too.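

In this assay compound 3 gives > 100000 nM, a limit of the assay and not a number. The steps from compound 1 and from compound 2 to compound 3 therefore cannot be read: the limit of > 100000 nM in this assay, at which 3 of the 3 values shown sit.

The compounds shown leave open whether any chain on the shared core gives a readable number in this assay, and how chain length would then change it.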